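Swapping in a 5-nitrothiophen-3-yl group: what to expect

The source may hold more compounds than are shown below. What is called first, only, known or untested is meant among the compounds shown, and "the series" means these compounds.

Compound 1 `O=C(/C(=C\c1ccc(Cl)cc1)S(=O)(=O)c1ccc(Br)cc1)c1ccc(Br)cc1`: 50000 nM
Compound 2 `O=C(/C(=C\c1ccc(F)c([N+](=O)[O-])c1)S(=O)(=O)c1ccc(Br)cc1)c1ccc(Br)cc1`: 25000 nM
Compound 3 `O=C(/C(=C\c1ccc(Br)c(O)c1)S(=O)(=O)c1ccc(Br)cc1)c1ccc(Br)cc1`: 50000 nM

These numbers come from a functional assay on DU-145 cells (Homo sapiens) for inhibition, read by trypan blue exclusion, with a stated time of 96 h; on this read-out higher numbers stand for weaker inhibition of growth and lower numbers for stronger inhibition of growth. There, compound 3 gives 50000 nM, the same number as compound 1, and compound 2 lies within the scatter of both.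

The next compound to be tested is compound 4 `O=C(/C(=C\c1csc([N+](=O)[O-])c1)S(=O)(=O)c1ccc(Br)cc1)c1ccc(Br)cc1`. It carries 5-nitrothiophen-3-yl in place of 4-bromo-3-hydroxyphenyl on a double-bonded chain carbon bound to a double-bonded chain carbon.

For the measured compounds named here, no measured compound carries this group, so the evidence is indirect. Three measured steps exchange the group at this same place. They are a 2.0-fold lower number from compound 1 to compound 2 (0.30 log units; within the scatter), no change at the digits printed from compound 1 to compound 3 (within the scatter) and a 2.0-fold higher number from compound 2 to compound 3 (0.30 log units; within the scatter). All three stay within the scatter, even though the groups exchanged differ in their substituents. None of them, however, involves a five-membered ring, so a larger step cannot be ruled out.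

With that caution, no step beyond the scatter is expected in this assay. The expected change is a 1.4-fold lower number from compound 3 to compound 4 (0.15 log units; within the scatter). For compound 4 the estimated value is 35000 nM. The expected range runs from 12000 nM to 70000 nM.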

Compound 4, concentration for 50% growth inhibition: 1000 nM
Compound 4: the middle estimate sits 35-fold (1.54 log units) above what was measured, outside the stated range (below it).
By their numbers in this assay, from the lowest: compound 4; then compounds 2, 1 and 3 (each within the scatter of the next).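

In this assay this place, on a double-bonded chain carbon bound to a double-bonded chain carbon, showed no clear response while only six-membered rings were exchanged, but it now proves highly sensitive: 5-nitrothiophen-3-yl gives a 50-fold lower number from compound 3 to compound 4 (1.70 log units; beyond the scatter), a 25-fold lower number from compound 2 to compound 4 (1.40 log units; beyond the scatter) and a 50-fold lower number from compound 1 to compound 4 (1.70 log units; beyond the scatter). For the compounds shown here, compound 4 is therefore the most potent of the four at inhibiting growth, the only one whose steps to all the others lie beyond the scatter. A nitro group alone does not bring this gain among these compounds: compound 2 carries one on its six-membered ring, yet it stays within the scatter of compound 1 and compound 3.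

The five-membered ring and the nitro group enter together, so the compounds shown cannot separate their contributions; a plain thiophen-3-yl group, or a thiophene ring bearing an amine or a carboxylic acid in place of the nitro group, would be needed to tell them apart. Nothing available here accounts for the size of this gain.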